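Swapping an Anilino Group for a Fluorophenyl Ring

This account rests on a few compounds, and the source may have more. Where it says the series, first, only, none or still open, it means among the compounds named here.

Compound 1 `C=C[C@@](C)(/C=C/c1ccc(O)cc1)CC/C=C(C)/C=C/C(=O)OCC`: 815 nM
Compound 2 `C=C[C@@](C)(/C=C/c1ccc(Nc2ccc(OC)cc2)cc1)CCC=C(C)C`: > 43400 nM
Compound 3 `C=C[C@@](C)(/C=C/c1ccc(Nc2ccc(OC)c(OC)c2)cc1)CCC=C(C)C`: > 43400 nM

In a functional assay on NALM-6 cells (Homo sapiens) for cytotoxicity, with a stated time of 72 h (on this read-out higher numbers stand for an effect only at larger amounts of compound and lower numbers for an effect already at smaller amounts), compound 1 gives 815 nM. Compound 2 reaches only a limit of the assay, > 43400 nM. Compound 3 likewise stops at a limit, > 43400 nM. The step that the two limits leave unreadable from compound 2 to compound 3 therefore cannot be read, and the ceiling the limit of > 43400 nM in this assay, at which 2 of the 3 values shown sit, holds two of the three values. Compound 4 `C=C[C@@](C)(/C=C/c1ccc(-c2cccc(F)c2)cc1)CCC=C(C)C` arises from compound 2 by 3-fluorophenyl in place of (4-methoxyphenyl)amino on an aromatic carbon. No measured step bears directly on this change: the only step shown is unreadable, and compound 1 differs from compound 2 in more than one place. Compound 4 is therefore expected to remain weak, with a step of an at least 1.7-fold lower number from compound 2 to compound 4 (0.23 log units; that floor lies within the scatter) that cannot be judged against the scatter. Compound 4 is estimated at 25000 nM, between 5000 nM and 60000 nM.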

Compound 4, half-maximal effective concentration: > 43400 nM
Compound 4 gave a limit, no number; the forecaster's own chance of this, stated with the estimate: 55%; middle value at least 1.7-fold (0.23 log units) away from the limit.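

In this assay, among these compounds, compound 2 and compound 4 both stop at a limit, so no step between them can be read: the limit of > 43400 nM in this assay, at which 3 of the 4 values shown sit. The compounds shown leave open whether 3-fluorophenyl in place of (4-methoxyphenyl)amino changes the effect at all.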